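Trimethoxyphenyl amides: replacing cyclopropyl with bromopropenyl

A few compounds are considered here, and "the series" means these few. Any claim that something is new, unique, unknown or untested is made for them only; others in the source may bear on it.

Measured compounds:
compound 1 `COc1ccc(CN(C(=O)C2CC2)c2cc(OC)c(OC)c(OC)c2)cc1O` — 59 nM
compound 2 `COc1ccc(CNc2cc(OC)c(OC)c(OC)c2)cc1C` — 56800 nM
compound 3 `C/C=C/C(=O)N(Cc1ccc(OC)c(Cl)c1)c1cc(OC)c(OC)c(OC)c1` — 7100 nM

In a functional assay on MGC-803 cells (Homo sapiens) for inhibition, read by MTT assay, with a stated time of 48 h (on this read-out lower numbers stand for stronger inhibition and higher numbers for weaker inhibition), compound 1 stands lowest of the three numbers. Its nearest neighbour is compound 3, whose value of 7100 nM lies far beyond the scatter above it, and compound 2, at 56800 nM, lies further still. For the measured compounds named here, no single-point step between measured compounds is available, so what separates compound 1 from the other two cannot be assigned to any one change.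

Compound 4 `COc1ccc(CN(C(=O)/C=C/CBr)c2cc(OC)c(OC)c(OC)c2)cc1O` is the next compound to be measured. It differs from compound 1 in one place: 3-bromoprop-1-en-1-yl in place of cyclopropyl on a carbonyl carbon. Nothing measured here isolates that change on the shared core. Compound 3 carries an unsaturated acyl group as well, but its benzyl ring also differs from that of compound 1, so its value gives only a loose hint.

Compound 4 is therefore expected to lose some ground against compound 1 in this assay, a step of a 5.1-fold higher number from compound 1 to compound 4 (0.71 log units; beyond the scatter) that is modest and uncertain. The estimate for compound 4 is 300 nM, with a likely range from 50 nM to 2000 nM.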

Compound 4, half-maximal inhibitory concentration: 71 nM
Compound 4: middle estimate off by 4.2-fold (0.63 log units), on the high side; the measured number falls inside the stated range.
By their numbers in this assay, from the lowest: compounds 1 and 4 (each within the scatter of the next); then compound 3; then compound 2.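

In this assay, putting 3-bromoprop-1-en-1-yl in place of cyclopropyl on a carbonyl carbon gives a 1.2-fold higher number from compound 1 to compound 4 (0.08 log units; within the scatter), so the read-out does not separate the two compounds. For the compounds shown here, this is the first comparison in which only this acyl substituent varies on the shared core, and it shows that the three-membered ring can give way to an open chain with a double bond and a bromine without a step beyond the scatter. The earlier compounds differed from one another in more than one place and could not show this, and no evidence is available that accounts for the two groups reading alike.

The compounds shown leave open which part of the new group matters, since neither the plain prop-1-en-1-yl group without bromine nor a saturated 3-bromopropyl chain appears among them on this core. As far as these compounds go, it also remains open how far this tolerance extends, for instance whether a longer chain or a chain ending in an amine or a carboxylic acid at the same carbonyl carbon would keep the number in this range in this assay.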